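This account rests on a few compounds, and the source may have more. Where it says the series, first, only, none or still open, it means among the compounds named here.

Measured in a functional assay on HeLa cells (Homo sapiens) for antiproliferative activity, read by WST assay, with a stated time of 24 h; a higher number here means a weaker inhibitor, a lower number a stronger inhibitor:
- compound 1 `C=C[C@]1(C)CC[C@@H](C(=C)CNC(C)(C)C)C[C@H]1C(=C)C`: 25400 nM
- compound 2 `C=C[C@]1(C)CC[C@@H](C(=C)COCCOC)C[C@H]1C(=C)C`: 238000 nM
- compound 3 `C=C[C@]1(C)CC[C@@H](C(=C)CNC2CCCCC2)C[C@H]1C(=C)C`: 3390 nM

Of these three, compound 3 has the lowest number, which makes it the strongest inhibitor so far. Compound 4 `C=C[C@]1(C)CC[C@@H](C(=C)CNC2CCCC2)C[C@H]1C(=C)C` carries cyclopentyl in place of cyclohexyl on an amine nitrogen. The most relevant evidence is a 7.5-fold lower number from compound 1 to compound 3 (0.87 log units; beyond the scatter), a modest step that also changes only the group on an amine nitrogen. The large 70-fold lower number from compound 2 to compound 3 (1.85 log units; beyond the scatter) and the modest 9.4-fold higher number from compound 1 to compound 2 (0.97 log units; beyond the scatter) replace the whole amino group or its ether counterpart, so they say less. Among the measured compounds shown here, no compound yet tests ring size. A small rise is therefore expected in this assay, possibly not beyond the scatter: the estimate is a 1.8-fold higher number from compound 3 to compound 4 (0.25 log units; within the scatter). For compound 4 the expected value is 6000 nM, with an estimated range of 2000 nM to 18000 nM.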

Compound 4, half-maximal inhibitory concentration: 520 nM
For compound 4 the middle estimate is 12-fold (1.06 log units) above the measured one, and the stated range ends above it.
By their numbers in this assay, from the lowest: compound 4; then compound 3; then compound 1; then compound 2.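

In this assay, ring size on the amine nitrogen turns out to matter: cyclopentyl in place of cyclohexyl gives a 6.5-fold lower number from compound 3 to compound 4 (0.81 log units; beyond the scatter), so losing a single ring carbon counts. Cyclopentyl also stands well clear of the tert-butyl amine, with a 49-fold lower number from compound 1 to compound 4 (1.69 log units; beyond the scatter), and of the ether, with a 460-fold lower number from compound 2 to compound 4 (2.66 log units; beyond the scatter). No measurement here explains why the smaller ring gives the lower number.

Still open, from the compounds shown here alone, is whether cyclobutyl on the same nitrogen would lower the number further. Going by these compounds, it is also open whether an open chain such as n-pentyl would match the cyclopentyl ring.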